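Removing One Chloro Group from Compound 1

The source may hold more compounds than are shown below. What is called first, only, known or untested is meant among the compounds shown, and "the series" means these compounds.

Measured compounds:
compound 1 `Nc1nc(O)c2c(n1)n(C1OC(CO)[C@@H](O)[C@H]1O)c(=O)n2Cc1ccc(Cl)c(Cl)c1` – 55%
compound 2 `Cn1c(=O)n2c3c1c(=O)nc(N)n3CC1OC2[C@H](O)[C@@H]1O` – 9%
compound 3 `C=CCn1c(=O)n(CCC(CCOCc2ccccc2)CCOCc2ccccc2)c2nc(N)nc(O)c21` – 68%

Of the compounds shown here, three have been measured in a functional assay on the whole organism (B cells) with Mus musculus as the target; a higher number here means a larger maximal response, a lower number a smaller maximal response. Compound 1 gives 55% and stands second highest of the three. Compound 3 gives 68%; the gap between compound 1 and compound 3 is beyond the scatter. Compound 2 gives 9%; the gap between compound 1 and compound 2 is also beyond the scatter. Going by the values given here, no pair of these three differs in only one place, so none of them shows what a single change does.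

The next compound, compound 4 `Nc1nc(O)c2c(n1)n(C1OC(CO)[C@@H](O)[C@H]1O)c(=O)n2Cc1ccc(Cl)cc1`, keeps the core and the sugar-like portion of compound 1 and differs only on the benzyl ring: hydrogen in place of chloro on an aromatic carbon.

Among the compounds with values here, there is no measured step of this kind to lean on. The change removes one heavy atom and leaves the rest of compound 1 untouched, so the step is expected to be small, perhaps a slight loss, and most likely not beyond the scatter. The expected step in this assay is a number 7 percentage points lower from compound 1 to compound 4 (within the scatter). Compound 4 is therefore estimated to reach 48%, with a range from 30% to 65%.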

Compound 4, largest response reached (reported as maximal response), in percent of the reference or control that the assay uses: 15%
For compound 4 the middle estimate is 33 percentage points above the measured one; measured number below the stated range.
By their numbers in this assay, from the lowest: compounds 2 and 4 (each within the scatter of the next); then compound 1; then compound 3.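

In this assay, going by these compounds alone, the one comparison in which only a single place differs shows that this position matters: hydrogen in place of chloro on an aromatic carbon, ortho to a chloro group and meta to a large group, gives a number 40 percentage points lower from compound 1 to compound 4 (beyond the scatter) with the core and the sugar-like portion unchanged. The earlier compounds shown here differed in several places at once and could not tie any change in maximal response to one atom, whereas here 3,4-dichlorobenzyl and 4-chlorobenzyl are clearly not interchangeable. Nothing measured on these compounds explains why this single exchange has so large an effect.

The compounds shown leave open whether a fluoro, a methyl or a methoxy group on this aromatic carbon would keep the response of compound 1 or lose it as compound 4 does, and whether the remaining chloro group matters as much as the one removed. They also leave open whether the same exchange would have a step of this size if a longer chain stood in place of the sugar-like portion.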